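Replacing Nitro by Chloro in a Vero Cytotoxicity Series

The source may report more compounds than this note shows. Statements on the series, on what has been measured and on what is new or still open speak of the compounds shown alone.

Going by the values given here, compound 2 `N/C(=N/NC(CC(=O)c1ccc(-n2ccnc2)cc1)c1cccc([N+](=O)[O-])c1)c1ccccn1` is one of two compounds measured so far in an ADME assay on Vero cells (Chlorocebus sabaeus) for cytotoxicity, read by MTT assay, with a stated time of 72 h; on this read-out higher numbers stand for lower toxicity in this test and lower numbers for higher toxicity in this test; compound 2 gives 28700 nM, and compound 1 `N/C(=N/NC(CC(=O)c1ccc(-n2ccnc2)cc1)c1ccc(Cl)cc1Cl)c1ccccn1` gives 27800 nM. Among the compounds with values here, the one measured step, a 1.0-fold higher number from compound 1 to compound 2 (0.01 log units; within the scatter), exchanged one aryl group for another without moving the number beyond the scatter. Compound 3 `N/C(=N/NC(CC(=O)c1ccc(-n2ccnc2)cc1)c1cccc(Cl)c1)c1ccccn1` differs from compound 2 by chloro in place of nitro on an aromatic carbon. Within the data shown here, since the only comparable step, an aryl exchange, stayed within the scatter, no shift beyond the scatter is expected in this assay either. Compound 3 is therefore estimated at 28000 nM, with a range of 14000 nM to 56000 nM, an expected step of a 1.0-fold lower number from compound 2 to compound 3 (0.01 log units; within the scatter).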

Compound 3, half-maximal cytotoxic concentration: 68600 nM
Compound 3: the middle estimate sits 2.5-fold (0.39 log units) below what was measured; the whole stated range lies below it.
By their numbers in this assay, from the lowest: compounds 1 and 2 (each within the scatter of the next); then compound 3.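

In this assay, chloro in place of nitro on this aromatic carbon gave a 2.4-fold higher number from compound 2 to compound 3 (0.38 log units; beyond the scatter) and so moved the number beyond the scatter, which the aryl exchange from the earlier pair had not done. The 3-chlorophenyl group in place of 2,4-dichlorophenyl gave a 2.5-fold higher number from compound 1 to compound 3 (0.39 log units; beyond the scatter) in the same direction, a step of similar size. Nothing measured here explains either step. From the compounds shown here alone, whether fluoro, methoxy or an amine on the same carbon would track chloro or nitro remains open, as does whether 2-chlorophenyl or 4-chlorophenyl would keep the higher number.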